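A hydroxymethyl-to-carbamoyl swap on a chemokine receptor antagonist

The source may report more compounds than this note shows. Statements on the series, on what has been measured and on what is new or still open speak of the compounds shown alone.

Compound 1 `C[C@@H]1CC(c2cnc3c(C#N)nn([C@H](C)c4ccc(Cl)cc4Cl)c3n2)=CC[C@@H]1N1CCC[C@H]1CO` is measured in a functional assay on cells for antagonist activity at C-C chemokine receptor type 4 (Homo sapiens), read by fluorescence and calcium flux, with stated times of 2.5 s and 45 s (a higher number here means a weaker inhibitor, a lower number a stronger inhibitor), and gives 40 nM. Among the three measured compounds it carries the highest number, yet compound 2 `Cc1nn([C@H](C)c2ccc(Cl)cc2Cl)c2nc(C3=CC[C@H](N4CCC[C@H]4CO)[C@H](C)C3)cnc12` with 36 nM and compound 3 `Cc1nn([C@H](C)c2ccc(Cl)cc2Cl)c2nc(N3CC[C@H](N4CCC[C@H]4CCC(N)=O)[C@H](C)C3)cnc12` with 37 nM both sit within the scatter of it, so no order among the three can be claimed. Among the measured compounds shown here, the one measured single-point step, a 1.1-fold lower number from compound 1 to compound 2 (0.05 log units; within the scatter), changed nothing beyond the scatter. Compound 4 `C[C@@H]1CC(c2cnc3c(C#N)nn([C@H](C)c4ccc(Cl)cc4Cl)c3n2)=CC[C@@H]1N1CCC[C@H]1C(N)=O` differs from compound 1 by carbamoyl in place of hydroxymethyl on a saturated ring carbon. For the measured compounds named here, no measured step touches this exact change; compound 3, which carries a primary amide on its pyrrolidine ring, merely shows a number close to that of compound 1. Compound 4 is therefore expected to give about 60 nM, between 20 nM and 180 nM, with the estimated step of a 1.5-fold higher number from compound 1 to compound 4 (0.18 log units; within the scatter).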

Compound 4, half-maximal inhibitory concentration: 54 nM
The estimate for compound 4 lay 1.1-fold (0.05 log units) above the measured number; measured number inside the range.
By their numbers in this assay, from the lowest: compounds 2, 3, 1 and 4 (each within the scatter of the next).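

On the saturated ring carbon of the five-membered ring, carbamoyl in place of hydroxymethyl gives a 1.4-fold higher number from compound 1 to compound 4 (0.13 log units; within the scatter) and so stays within the scatter, which means this position tolerates the swap on the core of compound 1. Among the compounds shown here, the only other step, a 1.1-fold lower number from compound 1 to compound 2 (0.05 log units; within the scatter) and made at an aromatic carbon, says nothing about this ring carbon. No measurement here explains why the two groups read alike. Going by these compounds, whether a carboxylic acid, an amine or a longer chain would also be tolerated at this carbon remains open. So does whether carbamoyl would read the same on the core of compound 2.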